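From Chloro to Methyl in a Growth Assay

This account rests on a few compounds, and the source may have more. Where it says the series, first, only, none or still open, it means among the compounds named here.

Measured in a functional assay on NCI-H460 cells (Homo sapiens) for inhibition, read by sulforhodamine B assay, with a stated time of 48 h; on this read-out lower numbers stand for stronger inhibition of growth and higher numbers for weaker inhibition of growth:
compound 1 `CCOC(=O)c1nn(-c2ccc(Cl)cc2)c(-c2ccc(Cl)cc2)c1CNC(C)(C)C` gives 144000 nM; > 519000 nM (2 entries)
compound 2 `CC(C)(C)NCc1c(C(=O)O)nn(-c2ccccc2)c1-c1ccc(Cl)cc1` gives 70500 nM
compound 3 `CC(C)(C)NCc1c(C(=O)O)nn(-c2ccc(Cl)cc2)c1-c1ccc(Cl)cc1` gives > 599000 nM (a limit)

Compound 3 has no exact number here, since its > 599000 nM is a limit of the assay. Compound 4 `Cc1ccc(-c2c(CNC(C)(C)C)c(C(=O)O)nn2-c2ccc(Cl)cc2)cc1` differs from it in one group: methyl in place of chloro on an aromatic carbon. Put simply, this is methyl in place of chloro on an aromatic carbon, para to a large group.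

Among the measured compounds shown here, only one measured step bears on this change, and only indirectly. It is an at least 8.4-fold higher number from compound 2 to compound 3 (0.92 log units; beyond the scatter), where chloro replaced hydrogen on a different aromatic ring. That step shows that one small substitution can shift the read-out well beyond the scatter, but it does not measure a swap of chloro for methyl. The entries (the several entries of compound 1 in this assay, 144000 nM; > 519000 nM (2 entries)), one of which is a limit, also show that readings for this series can be imprecise.

The estimated change, an at least 2.9-fold lower number from compound 3 to compound 4 (0.47 log units; beyond the scatter), is expected to point towards a lower number, though this assay may again return only a limit. For compound 4 the expected value is 200000 nM, with an estimated range from 50000 nM to 600000 nM.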

Compound 4, concentration for 50% growth inhibition: > 629000 nM
Compound 4: only a limit was reported (the forecaster's own chance of this, stated with the estimate: 45%); at least 3.1-fold (0.49 log units) between middle value and limit.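

In this assay compound 3 gives > 599000 nM, which is a limit. Among the compounds shown here, compound 4 gives > 629000 nM, again a limit, so the swap of chloro for methyl leaves no step that can be read between these two compounds. Going by these compounds, whether 4-chlorophenyl or 4-methylphenyl gives the lower number, and by how much, stays open.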